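The source may report more compounds than this note shows. Statements on the series, on what has been measured and on what is new or still open speak of the compounds shown alone.

In a functional assay on RAW264.7 cells (Mus musculus) for inhibition, read by Griess assay, with stated times of 2 h and 24 h (a higher number here means a weaker inhibitor, a lower number a stronger inhibitor), compound 1 `C/C1=C\CC(C)(C)/C=C/C(=O)[C@@H](CO)CCC1` gives 70600 nM while compound 2 `C/C1=C\CC(C)(C)/C=C/C(=O)[C@H](CO)CCC1` gives 33100 nM as the lower of the two numbers. For the measured compounds named here, the one measured step is a 2.1-fold lower number from compound 1 to compound 2 (0.33 log units; beyond the scatter) and comes with the fact that compounds 1 and 2 differ only in the configuration as drawn and so adds no group. Compound 3 `CO[C@H]1CC/C(C)=C/CC(C)(C)/C=C/C(=O)[C@@H]1CO` departs from compound 2 by methoxy in place of hydrogen on a saturated ring carbon in a new way: methoxy in place of hydrogen on a saturated ring carbon. Going by the values given here, no measured step covers such a change, so the modest 2.1-fold lower number from compound 1 to compound 2 (0.33 log units; beyond the scatter) is only a rough guide in this assay and a small step or none beyond the scatter is expected, with no firm direction. The expected 1.2-fold higher number from compound 2 to compound 3 (0.08 log units; within the scatter) is therefore small. For compound 3 the estimated value is 40000 nM within an expected range from 13000 nM to 100000 nM in this assay.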

Compound 3, half-maximal inhibitory concentration: 41400 nM
Beside the measured number, compound 3's estimate is 1.0-fold (0.01 log units) below it, and the stated range covers the measured number.
By their numbers in this assay, from the lowest: compounds 2, 3 and 1 (each within the scatter of the next, the first and the last beyond it).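

In this assay, methoxy in place of hydrogen on a saturated ring carbon, next to the ring atom that bears a hydroxymethyl group, gives a 1.3-fold higher number from compound 2 to compound 3 (0.10 log units; within the scatter), so this position takes the added group with no change beyond the scatter. For the compounds shown here, the earlier step concerned configuration alone, so this is the first reading of a group added to the shared core. Nothing on hand accounts for this outcome.

As far as these compounds go, whether a hydroxyl, an amine or a longer chain such as ethoxy at this ring carbon would read differently stays open, as does the opposite configuration of the methoxy-bearing carbon.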